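Chloro for Bromo on the Urea Aryl Ring

A few compounds are considered here, and "the series" means these few. Any claim that something is new, unique, unknown or untested is made for them only; others in the source may bear on it.

Three ureas built on one shared core have been measured in a functional assay on HepG2 cells (Homo sapiens) for antiproliferative activity, read by MTT assay, with a stated time of 48 h; a lower number here means a stronger inhibitor, a higher number a weaker inhibitor. Compound 1 `Cc1ccc(NC(=O)Nc2cccc(CNc3nccnc3Cl)c2)cc1C` gives 10700 nM there. Compound 2 `Cc1ccc(NC(=O)Nc2cccc(CNc3nccnc3Cl)c2)cc1` gives 11500 nM, and the step of a 1.1-fold higher number from compound 1 to compound 2 (0.03 log units; within the scatter) carries hydrogen in place of methyl on an aromatic carbon without moving the number beyond the scatter. Compound 3 `O=C(Nc1cccc(CNc2nccnc2Cl)c1)Nc1ccc(Cl)cc1Br` gives 6720 nM, the lowest of the three numbers, though neither neighbour stands apart from it: the step of a 1.6-fold lower number from compound 1 to compound 3 (0.20 log units; within the scatter) and the step of a 1.7-fold lower number from compound 2 to compound 3 (0.23 log units; within the scatter) both exchange the whole aryl group on the amide-type nitrogen and both stay within the scatter.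

Compound 4 `O=C(Nc1cccc(CNc2nccnc2Cl)c1)Nc1ccc(Cl)cc1Cl` follows from compound 3 by a single exchange, (chloro in place of bromo on an aromatic carbon). Among the measured compounds shown here, no measured step swaps one halogen for another on this ring; the only steps that touch this ring, a 1.6-fold lower number from compound 1 to compound 3 (0.20 log units; within the scatter) and a 1.7-fold lower number from compound 2 to compound 3 (0.23 log units; within the scatter), replaced far larger portions and still produced nothing beyond the scatter. The expectation is therefore a step of a 1.0-fold higher number from compound 3 to compound 4 (0.02 log units; within the scatter) in this assay, that is, no change beyond the usual spread. Compound 4 is accordingly estimated at 7000 nM, with a range from 3500 nM to 14000 nM.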

Compound 4, half-maximal inhibitory concentration: 7230 nM
Estimate against measurement, compound 4: 1.0-fold (0.01 log units) below, and the stated range covers the measured number.
By their numbers in this assay, from the lowest: compounds 3, 4, 1 and 2 (each within the scatter of the next).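

Among the compounds shown here, the exchange at this place on the ring, ortho to a large group, gives the first step in this assay that changes only the halogen: a 1.1-fold higher number from compound 3 to compound 4 (0.03 log units; within the scatter) shows that chloro and bromo are not told apart here. The two wider exchanges, a 1.6-fold lower number from compound 2 to compound 4 (0.20 log units; within the scatter) and a 1.5-fold lower number from compound 1 to compound 4 (0.17 log units; within the scatter), replace the whole aryl group and also stay within the scatter, so 2,4-dichlorophenyl, like 2-bromo-4-chlorophenyl, does not stand apart from the methyl-bearing aryl groups of compound 1 and compound 2 on the shared core. No measurement offered here speaks to what lies behind these flat steps.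

From the compounds shown here alone, all four compounds span only a narrow set of methyl, chloro and bromo aryl groups on one core, so it remains open whether this position responds at all in this assay or simply tolerates these two halogens. Whether a fluoro group, a methoxy group, a nitrile or an amine at this place on the ring would give a step beyond the scatter is left unanswered, as is the effect of a change elsewhere on the shared core.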